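This account rests on a few compounds, and the source may have more. Where it says the series, first, only, none or still open, it means among the compounds named here.

Working notes on the series, with all values from a functional assay on MGC-803 cells (Homo sapiens) for antiproliferative activity, read by CellTiter-Glo, with a stated time of 72 h (a higher number here means a weaker inhibitor, a lower number a stronger inhibitor), as follows:

- compound 1 `O=C(NO)c1cccc(/C=C/c2ccnc(-c3ccccc3O)c2)c1` at 2810 nM 
- compound 2 `O=C(NO)c1ccc(/C=C/c2ccnc(-c3ccccc3O)c2)cc1` at 1420 nM 

Among the compounds with values here, compound 2 stands at 1420 nM and compound 1 at 2810 nM as the only two numbers so far. These lie within the scatter of each other, so neither can be ranked.

Compound 3 `O=C(NO)c1ccc(/C=C/c2ccnc(-c3ccc(F)cc3)c2)cc1` has 4-fluorophenyl in place of 2-hydroxyphenyl on an aromatic carbon, next to the ring nitrogen. Within the data shown here, no measured pair isolates this change, so the expectation is weakly anchored and starts from compound 2 at 1420 nM alone.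

In this assay the expected step of a 1.1-fold lower number from compound 2 to compound 3 (0.04 log units; within the scatter) is none beyond the scatter, with no clear direction. The estimated value for compound 3 is 1300 nM with an expected range from 450 nM to 4000 nM.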

Compound 3, half-maximal inhibitory concentration: > 10000 nM
Compound 3: no number, only a limit (the forecaster's own chance of this, stated with the estimate: 5%); middle value at least 7.6-fold (0.88 log units) away from the limit.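

In this assay compound 3 gives > 10000 nM, which is a limit of the assay and not a number. Placing 4-fluorophenyl in place of 2-hydroxyphenyl on this aromatic carbon next to the ring nitrogen gives an at least 7.0-fold higher number from compound 2 to compound 3 (0.84 log units; beyond the scatter), the first step in the series beyond the scatter and the first sign that activity depends on the group held at this position. The step has a lower bound only, and its full size cannot be read: the limit of > 10000 nM in this assay, at which 1 of the 3 values shown sits.

The compounds shown do not separate the loss of the hydroxyl from the arrival of the fluorine, and an unsubstituted phenyl at this carbon would bear on that question. As far as these compounds go, whether the same change has a similar effect on the core of compound 1 also stays open.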